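This account rests on a few compounds, and the source may have more. Where it says the series, first, only, none or still open, it means among the compounds named here.

Measured values in a functional assay on HeLa cells (Homo sapiens) for cytotoxicity, read by WST assay, with a stated time of 48 h (on this read-out higher numbers stand for weaker inhibition and lower numbers for stronger inhibition), are as follows.
- compound 1 `COc1ccc([C@H](O)[C@H]2CO[C@@H](c3ccc(OC)c(OC)c3)[C@H](C/C=C/c3ccccc3)C2)cc1OC` gives 16100 nM
- compound 2 `COc1ccc([C@H](O)[C@H]2CO[C@H](c3ccc(OC)c(OC)c3)[C@@H](C/C=C/c3ccc(OC)c(OC)c3)C2)cc1` gives 46000 nM
- compound 3 `COc1ccc(/C=C/C[C@H]2C[C@@H]([C@@H](O)c3ccccc3)CO[C@@H]2c2ccc(OC)c(OC)c2)cc1OC` gives 15500 nM

Compound 2 (46000 nM) has the highest number of the three and is the weakest inhibitor here. Compound 1 and compound 3 lie within the scatter of each other, and each stands below compound 2 by more than the scatter.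

Compound 4 `COc1ccc([C@H](O)[C@H]2CO[C@@H](c3ccc(OC)c(OC)c3)[C@H](C/C=C/c3ccc(OC)c(OC)c3)C2)cc1` is still unmeasured. Its relation to compound 2 is purely one of configuration (the two compounds have the same atoms and bonds and differ only in configuration as drawn: 2 of 5 stereo elements differ; a stereocentre at a saturated ring carbon is drawn S in compound 2 and R in compound 4; a stereocentre at a saturated ring carbon is drawn S in compound 2 and R in compound 4). Both changed stereocentres sit at saturated ring carbons, drawn S in compound 2 and R in compound 4.

Within the data shown here, no measured step tests a change of configuration. Among the measured compounds shown here, the only single-place step available is hydrogen in place of methoxy on an aromatic carbon (a 3.0-fold lower number from compound 2 to compound 3 (0.47 log units; beyond the scatter)), and it is modest. That step gives a rough scale for this small series but no direction for the present change. The direction rests only on compound 2 (46000 nM) holding the highest of the three numbers, so a lower number is expected in this assay, by less than the measured step. The expected step is small (a 1.8-fold lower number from compound 2 to compound 4 (0.26 log units; within the scatter)). For compound 4 the estimated value is 25000 nM, with an expected range from 10000 nM to 60000 nM.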

Compound 4, half-maximal inhibitory concentration: 32200 nM
Beside the measured number, compound 4's estimate is 1.3-fold (0.11 log units) below it; the range from low to high includes it.
By their numbers in this assay, from the lowest: compounds 3, 1, 4 and 2 (each within the scatter of the next, the first and the last beyond it).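

In this assay, among these compounds, the first step that tests configuration alone reads a 1.4-fold lower number from compound 2 to compound 4 (0.15 log units; within the scatter), so changing the two stereocentres at saturated ring carbons, drawn S in compound 2 and R in compound 4, gives no readable difference in this pair. Nothing leaves or enters in this step, so no change of group is mixed into the comparison: the fact that compounds 2 and 4 differ only in the configuration as drawn. Among the compounds shown here, the only earlier single-place step, a 3.0-fold lower number from compound 2 to compound 3 (0.47 log units; beyond the scatter), involved hydrogen in place of methoxy on an aromatic carbon and lies beyond the scatter, whereas the configurational step does not, which shows that a change at these two stereocentres need not move the number by more than the scatter.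

Still open, as far as these compounds go, is whether either stereocentre would give a readable step if changed alone, as both change together here, and whether the other three stereo elements matter. Also open, from the compounds shown here alone, is how an amine or a carboxylic acid in place of a methoxy group would read in this assay, and whether such a step would depend on the configuration drawn in compound 2 or compound 4.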